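Notes on chloro additions in a small binding series

A few compounds are considered here, and "the series" means these few. Any claim that something is new, unique, unknown or untested is made for them only; others in the source may bear on it.

Measured compounds:
Compound 1 (`CC(C)(C)Cc1csc(N)c1C(=O)c1cccc(Cl)c1`): in an assay on CHO cells for displacement of a labelled ligand from adenosine receptor A3 (Homo sapiens), read by scintillation counting, tested at 10 uM (on this read-out lower numbers stand for less inhibition and higher numbers for more inhibition at the one concentration tested (going by the name of the read-out)), compound 1 gives 8%.
Compound 2 (`CC(C)(C)Cc1c(-c2ccc(Cl)cc2)sc(N)c1C(=O)c1ccc(Cl)cc1`): in this assay compound 2 gives 1%.
Compound 3 (`CC(C)(C)Cc1c(-c2ccc(Cl)c(Cl)c2)sc(N)c1C(=O)c1ccc(Cl)cc1`): in this assay compound 3 gives 1%.

All three numbers are low and lie within the scatter of one another, so no order among compounds 1, 2 and 3 can be read from them. Compound 2 and compound 3 differ in one place only, by chloro in place of hydrogen on an aromatic carbon, and that step reads no change at the digits printed from compound 2 to compound 3 (within the scatter). The difference between the core of compound 1 and the core of compound 2 is not broken down here; their two values merely sit close together.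

Compound 4 (`CC(C)(C)Cc1csc(N)c1C(=O)c1ccc(Cl)c(Cl)c1`) has not been measured. It differs from compound 1 by chloro in place of hydrogen on an aromatic carbon. Going by the values given here, this is the same kind of change as the one from compound 2 to compound 3, but not the same: around the entering chloro the place in compound 4 is para to a large group, where in compound 3 it is meta to a large group.

The expectation for compound 4 in this assay rests on the measured pair: because no change at the digits printed from compound 2 to compound 3 (within the scatter), the corresponding step is estimated as a number 2 percentage points lower from compound 1 to compound 4 (within the scatter), a step within the scatter. Compound 4 is therefore expected to give 6%, with a likely range from 0% to 16%.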

Compound 4, a percentage reported as inhibition, at one concentration (the size of the read-out at that concentration, not a potency): 10%
Estimate against measurement, compound 4: 4 percentage points below; the measured number falls inside the stated range.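

In this assay, chloro in place of hydrogen on an aromatic carbon, here para to a large group and ortho to a chloro group, gives a number 2 percentage points higher from compound 1 to compound 4 (within the scatter), so the change has now been read on two cores. Set beside the earlier step, the two readings do not differ: the same change on two cores in this assay, no change at the digits printed (within the scatter) from compound 2 to compound 3 and a number 2 percentage points higher (within the scatter) from compound 1 to compound 4, 2 percentage points apart, within the scatter of two such steps Within this series, the change therefore leaves the read-out within the scatter on both cores, but this does not show that a real effect of the change carries from one core to the other, since neither step lies beyond the scatter, the entering chloro does not stand in the same place in the two pairs, and a read-out at one concentration gives no potency.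

The compounds shown leave open whether a group other than chloro at this place on the ring, such as a nitrile, a methoxy group or a carboxylic acid, would move the number beyond the scatter. Also open, on these data alone, is whether an amine or a longer chain in place of the branched alkyl chain on the shared core would do so.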